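A few compounds are considered here, and "the series" means these few. Any claim that something is new, unique, unknown or untested is made for them only; others in the source may bear on it.

Measured in a functional assay on HepG2 cells (Homo sapiens) for antiproliferative activity, read by spectrophotometry, with a stated time of 2 days; a lower number here means a stronger inhibitor of growth, a higher number a weaker inhibitor of growth:
- Compound 1 `COc1ccc(Nc2ncc(C(F)(F)F)c(N3Cc4cccc(N(C)S(C)(=O)=O)c4C3)n2)cc1C(F)(F)F`: > 30000 nM
- Compound 2 `COc1cc(N2CCN(C(C)=O)CC2)ccc1Nc1ncc(C(F)(F)F)c(N2Cc3cccc(N(C)S(C)(=O)=O)c3C2)n1`: 3800 nM
- Compound 3 `CN(c1cccc2c1CN(c1nc(Nc3cc(C(F)(F)F)cc(C(F)(F)F)c3)ncc1C(F)(F)F)C2)S(C)(=O)=O`: 10300 nM

Compound 1 stands at the weak end of this short series, and it has no exact number. Its reading of > 30000 nM is a limit of this assay, not a measured value. This is the only such case among the three compounds: the limit of > 30000 nM in this assay, at which 1 of the 3 values shown sits.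

Compound 4 `COc1cc(Nc2ncc(C(F)(F)F)c(N3Cc4cccc(N(C)S(C)(=O)=O)c4C3)n2)cc(OC)c1` keeps the core of compound 1 and changes one group: 3,5-dimethoxyphenyl in place of 4-methoxy-3-(trifluoromethyl)phenyl on a nitrogen on an aromatic ring.

Going by the values given here, no pair of measured compounds differs in only one place, so the data give no direct size for such a change. The nearest guide comes from the two other compounds, which share this core but carry other groups at that place. Compound 3 gives 10300 nM, and compound 2 gives 3800 nM. Both of these are real numbers, so a modest gain in growth inhibition is expected, though compound 4 could also end up at the limit. As a step, the estimate means an at least 2.5-fold lower number from compound 1 to compound 4 (0.39 log units; beyond the scatter), an expected move toward stronger inhibition. For compound 4 the estimated value is 12000 nM, with an expected range from 4000 nM to 30000 nM.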

Compound 4, concentration for 50% growth inhibition: 1800 nM
Compound 4: the middle estimate sits 6.7-fold (0.82 log units) above what was measured; the measured number lies below the stated range.
By their numbers in this assay, from the lowest: compound 4; then compound 2; then compound 3. At a limit, above all of these: compound 1.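

Going by these compounds alone, this is the first pair of compounds that differ in only one place, so the group on a nitrogen on an aromatic ring now has a direct measure: in this assay, 3,5-dimethoxyphenyl in place of 4-methoxy-3-(trifluoromethyl)phenyl gives an at least 16-fold lower number from compound 1 to compound 4 (1.22 log units; beyond the scatter). The size of this step is a minimum and not an exact figure, since the reading for compound 1 is a limit of the assay and not a number: the limit of > 30000 nM in this assay, at which 1 of the 4 values shown sits. The group that leaves carries one trifluoromethyl and one methoxy, while the group that enters carries two methoxy groups, so this single step changes both features at once and cannot show which of them accounts for the gain.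

The compounds shown leave open whether other aryl groups at this place, such as a phenyl ring bearing an amine or a carboxylic acid, would give a lower or a higher number than compound 4. They also leave open whether 3,5-dimethoxyphenyl would give a step of similar size on a core other than the one shared here.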